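From Methyl to tert-Butoxycarbonyl on a Ring Nitrogen

The source may report more compounds than this note shows. Statements on the series, on what has been measured and on what is new or still open speak of the compounds shown alone.

Compound 1 `COc1ccc(N2CCN(Cc3ccc4c(c3O)-c3ccc(cc3O)CCc3ccc(O)c(c3)Oc3ccc(cc3)CC4)CC2)cc1`: > 20000 nM (a limit)
Compound 2 `Oc1ccc2cc1Oc1ccc(cc1)CCc1ccc(CN3CCN(Cc4ccccc4)CC3)c(O)c1-c1ccc(cc1O)CC2`: > 20000 nM (a limit)
Compound 3 `CN1CCN(Cc2ccc3c(c2O)-c2ccc(cc2O)CCc2ccc(O)c(c2)Oc2ccc(cc2)CC3)CC1`: 6020 nM

All three results come from a functional assay on MCF7 cells (Homo sapiens) for antiproliferative activity, read by MTT assay, with a stated time of 48 h; on this read-out lower numbers stand for stronger inhibition and higher numbers for weaker inhibition. Among them, compound 3 holds the only true number, 6020 nM. The other two results are limits, not numbers: the limit of > 20000 nM in this assay, at which 2 of the 3 values shown sit.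

Compound 4 `CC(C)(C)OC(=O)N1CCN(Cc2ccc3c(c2O)-c2ccc(cc2O)CCc2ccc(O)c(c2)Oc2ccc(cc2)CC3)CC1` has tert-butoxycarbonyl in place of the methyl of compound 3 on an amine nitrogen in a ring: tert-butoxycarbonyl in place of methyl on an amine nitrogen in a ring.

For the measured compounds named here, two measured steps bear on this change, and both end at the methyl-bearing compound 3. The first is an at least 3.3-fold lower number from compound 1 to compound 3 (0.52 log units; beyond the scatter), and the second is an at least 3.3-fold lower number from compound 2 to compound 3 (0.52 log units; beyond the scatter). Their true sizes may be greater, since each starts from a limit. The remaining step, a step that the two limits leave unreadable from compound 1 to compound 2, adds nothing. Neither comparison involves tert-butoxycarbonyl, so they offer only a loose guide. Still, neither of the two other compounds matches compound 3, so leaving the methyl is expected to raise the number in this assay, reversing the direction of an at least 3.3-fold lower number from compound 1 to compound 3 (0.52 log units; beyond the scatter). The expected change is a 2.7-fold higher number from compound 3 to compound 4 (0.42 log units; beyond the scatter), towards weaker inhibition, and a result reported only as a limit is quite possible. Compound 4 is estimated at 16000 nM, with an expected range from 7000 nM to 35000 nM.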

Compound 4, half-maximal inhibitory concentration: > 20000 nM
Compound 4 gave a limit, no number; the forecaster's own chance of this, stated with the estimate: 55%; at least 1.2-fold (0.09 log units) between middle value and limit.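

In this assay, for the compounds shown here, the replacement gives an at least 3.3-fold higher number from compound 3 to compound 4 (0.52 log units; beyond the scatter) and so extends what the earlier compounds showed. Going by these compounds alone, until now, the only groups seen in place of the methyl on this ring nitrogen were 4-methoxyphenyl and benzyl, each of which carries a ring; tert-butoxycarbonyl has no ring, yet compound 4 also falls short of compound 3. Compound 3 therefore remains the only one of the four with a true number, while the three compounds with a larger group on this nitrogen now share one assay limit: the limit of > 20000 nM in this assay, at which 3 of the 4 values shown sit.

The steps from compound 1 to compound 4 and from compound 2 to compound 4 cannot be read, so 4-methoxyphenyl, benzyl and tert-butoxycarbonyl cannot be ranked against one another. From the compounds shown here alone, it also stays open whether compound 3 with its 6020 nM would be matched or surpassed by a compound with a plain hydrogen, an ethyl group or an acetyl group on that ring nitrogen.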